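The source may hold more compounds than are shown below. What is called first, only, known or untested is meant among the compounds shown, and "the series" means these compounds.

Measured in an in vitro functional assay on 1321-N1 cells for agonist activity at P2Y purinoceptor 6 (Homo sapiens), read by scintillation proximity assay and inositol phosphate accumulation; on this read-out lower numbers stand for an effect already at smaller amounts and higher numbers for an effect only at larger amounts of compound:
compound 1, `COc1nc(=O)ccn1[C@@H]1O[C@H](COP(=O)(O)OP(=O)(O)O)[C@@H](O)[C@H]1O`: 1370 nM
compound 2, `O=c1ccn([C@@H]2O[C@H](COP(=O)(O)OP(=O)(O)O)[C@@H](O)[C@H]2O)c(SCc2ccccc2)n1`: 6800 nM
compound 3, `O=c1ccn([C@@H]2O[C@H](COP(=O)(O)O)[C@@H](O)[C@H]2O)c(SCc2ccccc2)n1`: > 100000 nM, a limit of the assay, not a number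

Two changes run through the set. The first is methoxy in place of benzylsulfanyl on an aromatic carbon; it gives a 5.0-fold lower number from compound 2 to compound 1 (0.70 log units; beyond the scatter). The second is the change of core, (a hydrogen atom in place of a group of 4 heavy atoms (3 oxygen, 1 phosphorus; no ring), on an oxygen); it gives an at least 14-fold higher number from compound 2 to compound 3 (1.16 log units; beyond the scatter), the size of which is known only as a lower bound because of the limit of > 100000 nM in this assay, at which 1 of the 3 values shown sits. For compound 3 this assay reports only a limit, so where compound 3 truly stands is open.

Compound 4, `COc1nc(=O)ccn1[C@@H]1O[C@H](COP(=O)(O)O)[C@@H](O)[C@H]1O`, has not yet been measured in this assay. It carries the same change from compound 3 that compound 1 carries from compound 2: methoxy in place of benzylsulfanyl on an aromatic carbon. The place line of this change reads the same in both pairs, so it is the same change, not merely the same kind. Compound 4 thus combines the core of compound 3 with the methoxy of compound 1.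

The expectation for compound 4 rests on two points: the step of a 5.0-fold lower number from compound 2 to compound 1 (0.70 log units; beyond the scatter), which on the core of compound 2 was modest, and the limit of compound 3, which leaves the starting point uncertain. The estimate for compound 4 therefore means a step of an at least 1.6-fold lower number from compound 3 to compound 4 (0.22 log units; that floor lies within the scatter), applied to a value that is itself only a bound. Compound 4 is expected at about 60000 nM, within a range from 15000 nM to 300000 nM, with a fair chance that this assay again returns only a limit.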

Compound 4, half-maximal effective concentration: 9800 nM
Compound 4: middle estimate off by 6.1-fold (0.79 log units), on the high side; measured number below the stated range.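

In this assay, methoxy in place of benzylsulfanyl lowers the number on both cores, with an at least 10-fold lower number from compound 3 to compound 4 (1.00 log units; beyond the scatter), so the direction of this change carries over on these two cores, though two cores set no rule for a third: the same change on two cores in this assay, a 5.0-fold lower number (0.70 log units; beyond the scatter) from compound 2 to compound 1 and an at least 10-fold lower number (1.00 log units; beyond the scatter) from compound 3 to compound 4; the limit leaves it open whether they differ

Compound 3 has > 100000 nM, a limit of the assay and not a number, so the size of the step on its core is only a floor and nothing shows that the change is larger there: the limit of > 100000 nM in this assay, at which 1 of the 4 values shown sits.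

The other change also keeps its direction once methoxy is in place, as a hydrogen atom in place of the group of 4 heavy atoms on the oxygen gives a 7.2-fold higher number from compound 1 to compound 4 (0.85 log units; beyond the scatter), and whether it costs the same on both cores stays unsettled: the same change on two cores in this assay, an at least 14-fold higher number (1.16 log units; beyond the scatter) from compound 2 to compound 3 and a 7.2-fold higher number (0.85 log units; beyond the scatter) from compound 1 to compound 4; the limit leaves it open whether they differ

On these data alone, only benzylsulfanyl and methoxy stand on this aromatic carbon, so it remains open how an amine, an ethoxy group or a shorter sulfanyl chain would read in this assay. Also open, as far as these compounds go, is how the same methoxy change would read with a longer phosphate chain on that oxygen, and where compound 3 truly stands.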